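Removing chloro: from compound 2 to compound 3

This account rests on a few compounds, and the source may have more. Where it says the series, first, only, none or still open, it means among the compounds named here.

Measured compounds:
compound 1 `Cc1ccc(C2CNN=C2S(=O)(=O)CC2=NCCS2)cc1` — 43.1%
compound 2 `O=S(=O)(CC1=NCCS1)C1=NNCC1c1ccc(Cl)cc1` — "not active" (no number reported)

Compound 2 `O=S(=O)(CC1=NCCS1)C1=NNCC1c1ccc(Cl)cc1` was reported in a functional assay, read by Griess assay, with a stated time of 150 min, tested at 50 ug/mL (on this read-out higher numbers stand for a stronger effect at the one concentration tested and lower numbers for a weaker effect), as "not active" (no number reported), so no single number fixes where it stands. Compound 1 `Cc1ccc(C2CNN=C2S(=O)(=O)CC2=NCCS2)cc1` gave 43.1% in this assay. Compound 3 `O=S(=O)(CC1=NCCS1)C1=NNCC1c1ccccc1` differs from compound 2 only by hydrogen in place of chloro on an aromatic carbon. Within the data shown here, no measured step of this kind exists, so the change expected in this assay is small: perhaps a modest rise from an inactive starting point, barely beyond the scatter, with another report of no activity quite possible. Compound 3 is estimated at 20%, within a range from 0% to 45%.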

Compound 3, a percentage reported as activity, at one concentration (the size of the read-out at that concentration, not a potency): "not active" (no number reported)
For compound 3 the study gives words and no number; no gap can be computed for the estimate.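

Compound 2 and compound 3 were both reported as not active, without a number, in this assay, so no step can be read between them. Going by these compounds, how much removing chloro changes the effect stays open. No other data bear on this result.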